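From compound 1 to compound 3: one added methyl

The source may report more compounds than this note shows. Statements on the series, on what has been measured and on what is new or still open speak of the compounds shown alone.

- compound 1 `N#Cc1c(N)cccc1Sc1ccccc1`: 168000 nM
- compound 2 `COc1cccc(Sc2cccc(N)c2C#N)c1`: > 200000 nM (a limit of the assay)

Going by the values given here, in a functional assay on MT4 cells (Homo sapiens) for cytotoxicity (a lower number here means a stronger inhibitor, a higher number a weaker inhibitor), compound 1 gives 168000 nM, the only actual number so far. Compound 2 gives only a limit, > 200000 nM. Among the compounds with values here, the single measured step, with methoxy in place of hydrogen, is an at least 1.1-fold higher number from compound 1 to compound 2 (0.07 log units; that floor lies within the scatter). Compound 3 `Cc1ccccc1Sc1cccc(N)c1C#N` carries a different change: methyl in place of hydrogen on an aromatic carbon. That measured step bears on it only loosely, so no step beyond the scatter is expected in this assay. Compound 3 is estimated at 170000 nM, with an expected range of 100000 nM to 260000 nM. The expected step is a 1.0-fold higher number from compound 1 to compound 3 (0.01 log units; within the scatter).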

Compound 3, half-maximal inhibitory concentration: > 40000 nM
Compound 3 was reported as a limit; the forecaster's own chance of this, stated with the estimate: 35%; the middle value lies beyond the limit too.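

Compound 3 gives only a limit, > 40000 nM, and its step from compound 1 cannot be read. The compounds shown leave open whether methyl in place of hydrogen on an aromatic carbon shifts the number in this assay at all.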